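The source may report more compounds than this note shows. Statements on the series, on what has been measured and on what is new or still open speak of the compounds shown alone.

In a functional assay on BGC-823 cells (Homo sapiens) for antiproliferative activity, read by MTT assay, with a stated time of 96 h (on this read-out lower numbers stand for stronger inhibition and higher numbers for weaker inhibition), compound 1 `COc1c(O)cc2cc1C[C@H](C)C[C@H](OC)[C@H](O)[C@@H](C)/C=C(\C)C[C@H](OC(N)=O)[C@@H](OC)CC/C=C(\C)C(=O)N2` gives 1760 nM, and compound 2 `COc1ccc([C@H]2c3cccc(c3O)NC(=O)/C(C)=C/C=C\[C@H](OC)[C@@H](OC(N)=O)/C(C)=C/[C@H](C)[C@@H](O)[C@@H](OC)C[C@@H]2C)cc1` gives 630 nM. On these two values, compound 2 is the stronger inhibitor. Compound 3 `COc1ccc([C@H]2c3cccc(c3O)NC(=O)/C(C)=C/CC[C@H](OC)[C@@H](OC(N)=O)/C(C)=C/[C@H](C)[C@@H](O)[C@@H](OC)C[C@@H]2C)cc1` gives > 20000 nM, which is a limit of the assay and not a number. Its position is therefore known only as a limit, and no exact potency can be read for it.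

Compound 4 `COc1ccc([C@H]2c3cccc(c3O)NC(=O)/C(C)=C/CC[C@H](OC)[C@@H](OC(N)=O)/C(C)=C/[C@H](C)[C@@H](OC)[C@@H](OC)C[C@@H]2C)cc1` differs from compound 3 in one place: methyl in place of hydrogen on an oxygen on a saturated carbon. This is a change from hydroxy to methoxy, with methyl in place of hydrogen on an oxygen on a saturated carbon. Among the compounds with values here, no measured pair shows this change on its own, so the series gives no direct guide to its size.

The expectation starts from compound 3 at > 20000 nM, again a limit. A single methyl in place of hydrogen is not expected to bring back measurable activity in this assay. The expected step that the limit leaves unreadable from compound 3 to compound 4 is small, with no gain beyond the scatter anticipated in either direction, and the assay may well report only a limit again. For compound 4 the estimated value is 30000 nM, with an expected range from 12000 nM to 60000 nM.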

Compound 4, half-maximal inhibitory concentration: > 20000 nM
Compound 4 ended at the assay's limit; the forecaster's own chance of this, stated with the estimate: 80%; the middle value does not contradict the limit.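

In this assay no step can be read from compound 3 to compound 4, since both sit at a limit of the assay and not at a number: the limit of > 20000 nM in this assay, at which 2 of the 4 values shown sit.

The compounds shown leave open how far the change from hydroxy to methoxy moves the value where a potency can be read.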